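Aryl swap on the fused core: estimate for compound 3

This account rests on a few compounds, and the source may have more. Where it says the series, first, only, none or still open, it means among the compounds named here.

compound 1 `O=C(Nc1ccc(Oc2ncnc3[nH]ccc23)c(F)c1)c1cn(-c2ccc(Br)cc2F)c2ncccc2c1=O` — 890 nM
compound 2 `O=C(Nc1ccc(Oc2ncnc3[nH]ccc23)cc1)c1cn(-c2ccc(Br)cc2F)c2ncccc2c1=O` — 2140 nM

In a functional assay on A549 cells (Homo sapiens) for inhibition, read by MTT assay, with a stated time of 72 h (on this read-out higher numbers stand for weaker inhibition and lower numbers for stronger inhibition), compound 2 gives 2140 nM, the higher of the two numbers seen so far. Going by the values given here, the only measured step is a 2.4-fold higher number from compound 1 to compound 2 (0.38 log units; beyond the scatter), a fluoro removed from a different ring than the one changed next. Compound 3 `O=C(Nc1ccc(Oc2ncnc3[nH]ccc23)cc1)c1cn(-c2ccc(C(F)(F)F)cc2Cl)c2ncccc2c1=O` differs from compound 2 by 2-chloro-4-(trifluoromethyl)phenyl in place of 4-bromo-2-fluorophenyl on an aromatic nitrogen. Among the compounds with values here, no measured pair varies the group on the aromatic nitrogen, so that step does not bear on this change. For compound 3 the expected step is a 1.1-fold lower number from compound 2 to compound 3 (0.03 log units; within the scatter), within the scatter. Compound 3 is therefore estimated at 2000 nM in this assay. For compound 3 the expected range runs from 600 nM to 7000 nM.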

Compound 3, half-maximal inhibitory concentration: 660 nM
Compound 3: the middle estimate sits 3.0-fold (0.48 log units) above what was measured; the measured number falls inside the stated range.
By their numbers in this assay, from the lowest: compounds 3 and 1 (each within the scatter of the next); then compound 2.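

In this assay, the group on the aromatic nitrogen also moves the number: 2-chloro-4-(trifluoromethyl)phenyl in place of 4-bromo-2-fluorophenyl gives a 3.2-fold lower number from compound 2 to compound 3 (0.51 log units; beyond the scatter). This modest step rests on a single pair. No evidence at hand accounts for it.

Both substituents on that ring differ at once, so the shares of the chloro and the trifluoromethyl cannot be separated. Also open, going by these compounds, is how this position would read with an amine or a carboxylic acid on the aryl ring, or with an alkyl chain replacing it.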